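Bromophenyl Replaces Fluorophenyl on the Shared Core

The source may hold more compounds than are shown below. What is called first, only, known or untested is meant among the compounds shown, and "the series" means these compounds.

Compound 3 `Nc1scc(-c2ccc(F)cc2)c1C(=O)c1ccccc1` stands level with compound 2 `Nc1scc(-c2cccc(F)c2)c1C(=O)c1ccccc1` at the digits shown, the two together the highest of three numbers: in a functional assay on CHO cells for agonist activity at adenosine receptor A1 (Homo sapiens), read by fluorescence and ERK phosphorylation, with stated times of 30 min and 1.5 h, tested at 3 uM (on this read-out lower numbers stand for a weaker effect and higher numbers for a stronger effect at the one concentration tested), compound 3 gives 51%, and compound 2 gives 51%. Compound 1 `Nc1scc(-c2ccccc2)c1C(=O)c1ccccc1` lies furthest from compound 3, and compound 1 gives 49%. Every measured step is small: a number 2 percentage points higher from compound 1 to compound 2 (within the scatter), a number 2 percentage points higher from compound 1 to compound 3 (within the scatter), and no change at the digits printed from compound 2 to compound 3 (within the scatter).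

Compound 4 `Nc1scc(-c2cccc(Br)c2)c1C(=O)c1ccccc1` differs from compound 3 in one place: 3-bromophenyl in place of 4-fluorophenyl on an aromatic carbon. Two of the known steps bear on this change, fluoro in place of hydrogen on an aromatic carbon and 4-fluorophenyl in place of 3-fluorophenyl on an aromatic carbon, and both lie within the scatter. Going by the values given here, no measured compound carries bromine, so the expectation rests on those small steps alone. Compound 4 is therefore expected to show no step beyond the scatter, no change at the digits printed from compound 3 to compound 4 (within the scatter). The estimated value for compound 4 is 51%, expected to fall between 38% and 64%.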

Compound 4, a percentage reported as activity, at one concentration (the size of the read-out at that concentration, not a potency): 67%
Compound 4: the middle estimate sits 16 percentage points below what was measured; the whole stated range lies below it.
By their numbers in this assay, from the lowest: compounds 1, 2 and 3 (each within the scatter of the next); then compound 4.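

Going by these compounds alone, on this aromatic carbon of the shared core, the earlier compounds showed only fluoro in place of hydrogen, with every step within the scatter; in this assay bromine gives the first step beyond it, at a number 18 percentage points higher from compound 1 to compound 4 (beyond the scatter) against the unsubstituted phenyl. With the ring place held, bromo in place of fluoro gives a number 16 percentage points higher from compound 2 to compound 4 (beyond the scatter) and so shows that the halogen itself matters here, while 3-bromophenyl in place of 4-fluorophenyl gives a number 16 percentage points higher from compound 3 to compound 4 (beyond the scatter) with a change of both halogen and ring place. Nothing available explains why the bromine compound stands apart.

As far as these compounds go, whether 4-bromophenyl would match compound 4 remains open, so the share of the ring place in this step is unsettled. Also open, from the compounds shown here alone, is how chlorine, iodine or a methyl group on the same phenyl ring would read at this one concentration.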